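This account rests on a few compounds, and the source may have more. Where it says the series, first, only, none or still open, it means among the compounds named here.

Compound 1, `CC(C)(C)OC(=O)Nc1ncc(C(Oc2cccc(C#N)c2)c2ccc(Cl)cc2)s1`, gives > 50000 nM in an ADME assay on HepG2 2.2.15 cells (Homo sapiens) for cytotoxicity (on this read-out lower numbers stand for higher toxicity in this test and higher numbers for lower toxicity in this test), which is a limit of the assay and not a number.
Compound 2, `CC(C)(C)OC(=O)Nc1ncc(C(Oc2ccc3cc(Br)ccc3c2)c2ccc(Cl)cc2)s1`, gives > 50000 nM in this assay, again a limit of the assay.
Compound 3, `COc1ccc(COC(c2ccccc2)c2cnc(NC(=O)c3cccs3)s2)cc1`, is recorded in this assay as "not toxic" (no number reported), without a number.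

Compound 2 therefore stands at the upper edge of what this assay reports; the same is true of compound 1, since (the limit of > 50000 nM in this assay, at which 2 of the 3 values shown sit). Among the compounds with values here, the one measured step, a step that the two limits leave unreadable from compound 1 to compound 2, is left unreadable by the two limits and sets no size. The next compound, compound 4, `N#Cc1cccc(C(=O)Nc2ncc(C(Oc3ccc4cc(Br)ccc4c3)c3ccc(Cl)cc3)s2)c1`, differs from compound 2 by 3-cyanophenyl in place of tert-butoxy on a carbonyl carbon. Within the data shown here, no measured step touches this change directly. Compound 3 does carry an amide on the same nitrogen of the shared core and is described in this assay as "not toxic" (no number reported), which gives no number to lean on. The expectation is that the step of a number no higher from compound 2 to compound 4 (the limit leaves the size open) will not move beyond the scatter. Compound 4 is thus expected at 50000 nM, with a range from 15000 nM to 100000 nM, most likely reported again only as a limit.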

Compound 4, half-maximal cytotoxic concentration: > 50000 nM
Compound 4: only a limit was reported; the forecaster's own chance of this, stated with the estimate: 70%; the middle value lies on the limit itself.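

Compound 2 and compound 4 both sit at a limit of this assay, so the step between them cannot be read: the limit of > 50000 nM in this assay, at which 3 of the 4 values shown sit.

The compounds shown leave open what concentration would reach the half-maximal cytotoxic effect for any of them, and whether 3-cyanophenyl in place of tert-butoxy changes it.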